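Changing the Halogenated Benzyl Group: Expected Shift in Binding

A few compounds are considered here, and "the series" means these few. Any claim that something is new, unique, unknown or untested is made for them only; others in the source may bear on it.

Compound 1 `O=C(O)c1nn(Cc2cc(Br)ccc2OCc2ccccc2)cc1F` gives 123 nM in an assay on CHO-K1 cells for displacement of a labelled ligand from prostaglandin E2 receptor EP1 subtype (Homo sapiens); on this read-out higher numbers stand for weaker inhibition and lower numbers for stronger inhibition.
Compound 2 `Cc1cc(C(=O)O)nn1Cc1cc(Br)ccc1OCc1ccc(Cl)cc1Cl` gives 0.132 nM in this assay.

Compound 2 has the lowest number of the two, and compound 1 stands far above it, beyond the scatter. Compound 3 `Cc1cc(C(=O)O)nn1Cc1cc(Br)ccc1OCc1cccc(Br)c1` is not yet measured; it differs from compound 2 by 3-bromophenyl in place of 2,4-dichlorophenyl on a saturated chain carbon bound to an oxygen on an aromatic ring. Within the data shown here, no measured pair shows this change alone, so its size is unknown from the data. A modest loss, that is a higher number, is expected for compound 3, with the step of a 7.6-fold higher number from compound 2 to compound 3 (0.88 log units; beyond the scatter). Compound 3 is estimated at 1 nM, within a range from 0.2 nM to 8 nM.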

Compound 3, half-maximal inhibitory concentration: 17.8 nM
Beside the measured number, compound 3's estimate is 18-fold (1.25 log units) below it; the measured number lies above the stated range.
By their numbers in this assay, from the lowest: compound 2; then compound 3; then compound 1.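

In this assay, replacing 2,4-dichlorophenyl with 3-bromophenyl gives a 130-fold higher number from compound 2 to compound 3 (2.13 log units; beyond the scatter). Among these compounds, this is the first change in the set made in one place alone, and it shows that binding depends strongly on which halogenated phenyl group sits on this saturated chain carbon. Nothing measured here explains the size of this step.

The compounds shown cannot separate the loss of the two chlorines from the gain of the bromine. From the compounds shown here alone, how a phenyl carrying a single chlorine, or a trifluoromethyl group in place of the bromine, would compare remains open.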